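From 4-nitrophenyl to pyridin-4-yl on a shared core

A few compounds are considered here, and "the series" means these few. Any claim that something is new, unique, unknown or untested is made for them only; others in the source may bear on it.

Measured in a physicochemical assay for lipophilicity, measured as octanol-water partition; on this read-out higher numbers stand for higher lipophilicity and lower numbers for lower lipophilicity:
- Compound 1 `O=C(NNc1ccnc2cc(Cl)ccc12)c1ccccc1/N=C/c1ccc(F)cc1`: 5.18
- Compound 2 `O=C(NNc1ccnc2cc(Cl)ccc12)c1ccccc1/N=C/c1ccccc1Cl`: 5.5
- Compound 3 `O=C(NNc1ccnc2cc(Cl)ccc12)c1ccccc1/N=C/c1ccc([N+](=O)[O-])cc1`: 4.58

Compound 3 has the lowest number of the three, and its gaps to both others lie beyond the usual scatter. The next compound, compound 4 `O=C(NNc1ccnc2cc(Cl)ccc12)c1ccccc1/N=C/c1ccncc1`, keeps the shared core and changes one group: pyridin-4-yl in place of 4-nitrophenyl on a carbon with a double bond to nitrogen. Pyridin-4-yl takes the place of 4-nitrophenyl on a carbon with a double bond to nitrogen.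

Two measured steps lead to this same 4-nitrophenyl group: a number 0.60 log units lower from compound 1 to compound 3 (beyond the scatter) and a number 0.92 log units lower from compound 2 to compound 3 (beyond the scatter). A third step at this place, a number 0.32 log units higher from compound 1 to compound 2 (beyond the scatter), shows that the number can also move upward. None of the three involves pyridin-4-yl, so the forecast for a ring with a hetero atom remains a judgement. A further fall in this assay, close in size to the largest measured step, is expected: a number 0.98 log units lower from compound 3 to compound 4 (beyond the scatter). Compound 4 is estimated at 3.6, with an expected range from 3 to 4.2.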

Compound 4, partition coefficient: 3.86
Compound 4: the middle estimate sits 0.26 log units below what was measured; measured number inside the range.
By their numbers in this assay, from the lowest: compound 4; then compound 3; then compound 1; then compound 2.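

In this assay, pyridin-4-yl gives the lowest number yet at this position, even against 4-nitrophenyl, the previous lowest: a number 0.72 log units lower from compound 3 to compound 4 (beyond the scatter). Against the two halogen-bearing rings the change is larger, a number 1.32 log units lower from compound 1 to compound 4 (beyond the scatter) and a number 1.64 log units lower from compound 2 to compound 4 (beyond the scatter), and both of these steps are large, so the position now covers a much wider span than the carbon-only rings showed. Nothing available here explains the size of these falls.

Going by these compounds alone, with only one ring that holds a hetero atom, the fall cannot yet be tied to that atom rather than to the loss of the other substituents. Where plain phenyl would fall remains open, as does whether 4-aminophenyl or 4-carboxyphenyl would lie above or below pyridin-4-yl.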